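Swapping Bromine for a Nitro Group on the Shared Core

The compounds below may be only part of what the source reports. "The series", "measured", "known", "first", "only" and "open" are said of these compounds alone.

Compound 1 `Cc1ccc2c(Cc3nn4cc(-c5ccc(Cl)cc5)nc4s3)coc2c1`: 8.38%
Compound 2 `Cc1ccc2c(Cc3nn4cc(-c5ccc(Br)cc5)nc4s3)coc2c1`: 6%

In a functional assay on the whole organism (strain Wistar albino) for inhibition, with Rattus norvegicus as the target, read by paw edema, with a stated time of 0.5 h, at a dose of 100 mg/kg by the oral route (a lower number here means less inhibition, a higher number more inhibition at the dose given (going by the name of the read-out)), compound 1 gives 8.38% and compound 2 gives 6%. Both numbers are small, so neither compound reduces the swelling much at the dose given. Among the measured compounds shown here, the only step measured so far, a number 2.4 percentage points lower from compound 1 to compound 2 (within the scatter), lies within the scatter, so the two compounds cannot be told apart. For the measured compounds named here, compound 2 stands at the bottom of the two numbers, with compound 1 as its only neighbour and the gap within the scatter.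

Compound 3 `Cc1ccc2c(Cc3nn4cc(-c5ccc([N+](=O)[O-])cc5)nc4s3)coc2c1` is not yet measured. (nitro in place of bromo on an aromatic carbon). Going by the values given here, the one measured step exchanges one halogen for another and says nothing about a nitro group, so no measured step bears directly on this change. With both measured numbers small and alike, no step beyond the scatter is expected, and the step of a number 2 percentage points higher from compound 2 to compound 3 (within the scatter) is an estimate only. Compound 3 is expected to give 8%, in a range from 0% to 20%.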

Compound 3, a percentage reported as inhibition, in the whole organism at one dose (the size of the read-out at that dose, not a potency): 0%
Beside the measured number, compound 3's estimate is 8 percentage points above it; the range from low to high includes it.
By their numbers in this assay, from the lowest: compounds 3, 2 and 1 (each within the scatter of the next).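

In this assay the position now carries a group that is not a halogen, and the exchange of 4-bromophenyl for 4-nitrophenyl gives a number 6 percentage points lower from compound 2 to compound 3 (within the scatter) on the shared core. Nitro in place of chloro gives a number 8.4 percentage points lower from compound 1 to compound 3 (within the scatter) and so cannot be told apart from no change either. Chloro, bromo and nitro on this aromatic carbon, para to a large group, therefore remain indistinguishable here, and the reduction in swelling stays small with all of them. No supporting measurement is available to explain this result.

From the compounds shown here alone, whether an amine or a carboxylic acid on this aromatic carbon would give a clearly larger reduction in swelling remains open. So does whether changes elsewhere on the shared core would do so.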